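Exchanging the Aryl Group on a Shared Core

This account rests on a few compounds, and the source may have more. Where it says the series, first, only, none or still open, it means among the compounds named here.

Of the compounds shown here, three built on one shared core have been measured in an assay on isolated protein for inhibition of Maltase-glucoamylase (Homo sapiens); a higher number here means a weaker inhibitor, a lower number a stronger inhibitor. Compound 1 `CCOc1cc(C(c2c(O)c3cc(C)ccc3oc2=O)c2c(O)c3cc(C)ccc3oc2=O)ccc1O` gives 221000 nM. Compound 2 `COc1ccc(C(c2c(O)c3cc(C)ccc3oc2=O)c2c(O)c3cc(C)ccc3oc2=O)cc1` gives 107000 nM, and the step of a 2.1-fold lower number from compound 1 to compound 2 (0.32 log units; beyond the scatter) lies beyond the scatter. Compound 3 `O=c1oc2ccc(Cl)cc2c(O)c1C(c1cccc(O)c1)c1c(O)c2cc(Cl)ccc2oc1=O` gives 84100 nM, the lowest of the three numbers shown; its gap to compound 2 lies within the scatter, while its gap to compound 1 lies beyond it.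

Compound 4 `COc1ccc(C(c2c(O)c3cc(Cl)ccc3oc2=O)c2c(O)c3cc(Cl)ccc3oc2=O)cc1OC` has not yet been measured. It differs from compound 3 in one place: 3,4-dimethoxyphenyl in place of 3-hydroxyphenyl on a saturated chain carbon bound to two aromatic carbons. For the measured compounds named here, one measured step bears on this change, a 2.1-fold lower number from compound 1 to compound 2 (0.32 log units; beyond the scatter), in which an aryl bearing a hydroxyl was likewise replaced by an aryl bearing methoxy on the same saturated chain carbon, and the number fell by a modest amount. Compound 3 and compound 2, which differ in both the aryl group and the core, sit within the scatter of each other, so the aryl group alone seems to shift this assay little among these compounds. The expected step is therefore a small one toward a lower number, or none beyond the scatter: a 1.2-fold lower number from compound 3 to compound 4 (0.08 log units; within the scatter). Compound 4 is thus estimated to give 70000 nM in this assay, with a range from 30000 nM to 170000 nM.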

Compound 4, half-maximal inhibitory concentration: 91400 nM
Compound 4: middle estimate off by 1.3-fold (0.12 log units), on the low side; the measured number falls inside the stated range.
By their numbers in this assay, from the lowest: compounds 3, 4 and 2 (each within the scatter of the next); then compound 1.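

In this assay, replacing 3-hydroxyphenyl with 3,4-dimethoxyphenyl on a saturated chain carbon bound to two aromatic carbons gives a 1.1-fold higher number from compound 3 to compound 4 (0.04 log units; within the scatter). On the core of compound 3, then, a group with 7 heavy atoms and 1 hydrogen-bond donor gives way to one with 10 heavy atoms and 0 hydrogen-bond donors, with no shift beyond the scatter, whereas the earlier exchange at this position on another core, also from an aryl bearing a hydroxyl to an aryl bearing methoxy, gave a 2.1-fold lower number from compound 1 to compound 2 (0.32 log units; beyond the scatter). Losing the hydroxyl at this position therefore does not by itself move the number beyond the scatter in every case, and no measurement shown here explains why the two steps differ in this respect.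

The compounds shown do not place the same aryl pair on both cores, so the part played by the core in how this position responds remains open. Also open, as far as these compounds go, is how the number would respond to an aryl group bearing an amine or a carboxylic acid at this position, since only hydroxyl and alkoxy groups appear on the aryl ring here.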